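This account rests on a few compounds, and the source may have more. Where it says the series, first, only, none or still open, it means among the compounds named here.

Compound 1 `CCCn1cc(-c2cc(OCC[C@@H]3NC(=O)N(C)CCCC/C=C\[C@@H]4C[C@@]4(C(=O)NS(=O)(=O)C4(C)CC4)NC3=O)c3ccc(OC)c(C)c3n2)cn1`: 62300 nM in an ADME assay on cells (Homo sapiens) for activation; a lower number here means that less compound is tolerated, a higher number that more compound is tolerated
Compound 2 `COc1ccc2c(OCC[C@@H]3NC(=O)N(C)CCCC/C=C\[C@@H]4C[C@@]4(C(=O)NS(=O)(=O)C4CC4)NC3=O)cc(-c3nc(C(C)C)cs3)nc2c1Cl`: 40400 nM in this assay
Compound 3 `COc1ccc2c(OCC[C@@H]3NC(=O)N(C)CCCC/C=C\[C@@H]4C[C@@]4(C(=O)NS(=O)(=O)C4(F)CC4)NC3=O)cc(-c3nc(C(C)C)cs3)nc2c1Cl`: 51400 nM in this assay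

Compound 1 gives the highest of the three numbers, but its gaps to compound 3 and to compound 2 are both within the scatter, so the three compounds are not separable here. Compound 4 `COc1ccc2c(OCC[C@@H]3NC(=O)N(C)CCCC/C=C\[C@@H]4C[C@@]4(C(=O)NS(=O)(=O)C4(C)CC4)NC3=O)cc(-c3nc(C(C)C)cs3)nc2c1C` has not yet been measured in this assay. It differs from compound 1 in one place: 4-isopropyl-1,3-thiazol-2-yl in place of 1-propyl-1H-pyrazol-4-yl on an aromatic carbon. Within the data shown here, the only single-change step measured, a 1.3-fold higher number from compound 2 to compound 3 (0.10 log units; within the scatter), concerns a different position and does not bear on this exchange. Compound 2 and compound 3 already carry the entering group and sit within the scatter of compound 1, so no step beyond the scatter is expected. Compound 4 is therefore estimated at 55000 nM, with a range of 30000 nM to 100000 nM, an expected step of a 1.1-fold lower number from compound 1 to compound 4 (0.05 log units; within the scatter).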

Compound 4, half-maximal cytotoxic concentration: 31900 nM
The estimate for compound 4 lay 1.7-fold (0.24 log units) above the measured number; the measured number falls inside the stated range.
By their numbers in this assay, from the lowest: compounds 4, 2, 3 and 1 (each within the scatter of the next).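

Among these compounds, at the aromatic carbon next to the ring nitrogen, the earlier compounds offered no single-change step; the exchange of 1-propyl-1H-pyrazol-4-yl for 4-isopropyl-1,3-thiazol-2-yl now supplies one, giving a 2.0-fold lower number from compound 1 to compound 4 (0.29 log units; within the scatter) in this assay and leaving the two groups unseparated. Both groups count the same heavy atoms, hydrogen-bond donors and acceptors, so the exchange alters the ring atoms and the chain on the ring without changing those counts. No evidence bears on the cause of this result.

Still open, as far as these compounds go, is whether an amine or a carboxylic acid on this five-membered ring would produce a step beyond the scatter.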